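A Methyl Added to the Other Phenyl of Compound 3

This account rests on a few compounds, and the source may have more. Where it says the series, first, only, none or still open, it means among the compounds named here.

Of the compounds shown here, three have been measured, and all share one core. Compound 1 `CC1=NN(c2ccccc2)C(=O)C12C=CC(=O)C=C2c1ccccc1` gives 17800 nM in a functional assay on HCT-116 cells (Homo sapiens) for antiproliferative activity, read by CCK-8 assay, with a stated time of 72 h; on this read-out lower numbers stand for stronger inhibition and higher numbers for weaker inhibition. Compound 2 `CC1=NN(c2ccc(C)cc2)C(=O)C12C=CC(=O)C=C2c1ccccc1` gives 16500 nM in this assay, a change of a 1.1-fold lower number from compound 1 to compound 2 (0.03 log units; within the scatter). Compound 3 `CC1=NN(c2cccc(Cl)c2)C(=O)C12C=CC(=O)C=C2c1ccccc1` gives 7000 nM in this assay, and its number is the lowest of the three: the step is a 2.5-fold lower number from compound 1 to compound 3 (0.41 log units; beyond the scatter) and a 2.4-fold lower number from compound 2 to compound 3 (0.37 log units; beyond the scatter), both beyond the scatter.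

Compound 4 `CC1=NN(c2cccc(Cl)c2)C(=O)C12C=CC(=O)C=C2c1ccc(C)cc1` differs from compound 3 by methyl in place of hydrogen on an aromatic carbon; cut one bond further out, the change reads phenyl to 4-methylphenyl, and this phenyl is the one attached to the core rather than the one on the amide-type nitrogen. For the measured compounds named here, the one measured step of the same kind, a 1.1-fold lower number from compound 1 to compound 2 (0.03 log units; within the scatter), stayed within the scatter, though there the methyl entered the ring on the amide-type nitrogen. Going by the values given here, no measured step touches the ring on the core. The expected step is therefore no change at the digits printed from compound 3 to compound 4 (within the scatter), nothing beyond the scatter. Compound 4 is estimated at 7000 nM in this assay, with a range from 3000 nM to 16000 nM.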

Compound 4, half-maximal inhibitory concentration: 2400 nM
Compound 4: middle estimate off by 2.9-fold (0.46 log units), on the high side; the whole stated range lies above it.
By their numbers in this assay, from the lowest: compound 4; then compound 3; then compounds 2 and 1 (each within the scatter of the next).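

This result shows that the phenyl attached to the shared core responds to a very small addition: in this assay, 4-methylphenyl in place of phenyl gives a 2.9-fold lower number from compound 3 to compound 4 (0.46 log units; beyond the scatter). So a single methyl, para to a large group on this ring, is enough to move the number beyond the scatter. The same change left the number within the scatter when it entered the ring on the amide-type nitrogen, so a methyl does not act alike everywhere in this small set, and the two steps differ both in the ring changed and in the rest of the molecule: the same change on two cores in this assay, a 1.1-fold lower number (0.03 log units; within the scatter) from compound 1 to compound 2 and a 2.9-fold lower number (0.46 log units; beyond the scatter) from compound 3 to compound 4, 2.7-fold (0.43 log units) apart, beyond the scatter of two such steps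

On these data alone, it remains open whether the methyl would lower the number on the core of compound 1, without the chloro group. As far as these compounds go, how an ethyl, a methoxy, an amine or a carboxylic acid would behave at this same place also remains open.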